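The source may hold more compounds than are shown below. What is called first, only, known or untested is meant among the compounds shown, and "the series" means these compounds.

In a functional assay on SW1573 cells (Homo sapiens) for antiproliferative activity, read by sulforhodamine B assay, with a stated time of 48 h (on this read-out higher numbers stand for weaker inhibition of growth and lower numbers for stronger inhibition of growth), compound 2 `Cc1ccc(S(=O)(=O)N2CCC(Br)=CC2C2CCCCC2)cc1` gives 65000 nM, the higher of the two numbers measured here; compound 1 `Cc1ccc(S(=O)(=O)N2CCC(Cl)=CC2c2ccccc2)cc1` gives 16000 nM, a clearly lower number. Compound 3 `Cc1ccc(S(=O)(=O)N2CCC(Br)=CC2c2ccccc2)cc1` has not been measured. Compared with compound 2, it carries phenyl in place of cyclohexyl on a saturated ring carbon, so it shares the phenyl group with compound 1 and the bromo group with compound 2. On this footing compound 3 is expected to move from compound 2 toward a lower number, by a step of roughly a 3.3-fold lower number from compound 2 to compound 3 (0.51 log units; beyond the scatter), somewhat beyond the scatter. The value of compound 3 is estimated at 20000 nM, within a range from 8000 nM to 50000 nM.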

Compound 3, concentration for 50% growth inhibition: 54000 nM
Compound 3: the middle estimate sits 2.7-fold (0.43 log units) below what was measured; measured number above the stated range.
By their numbers in this assay, from the lowest: compound 1; then compounds 3 and 2 (each within the scatter of the next).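

In this assay, with bromo on the ring, phenyl and cyclohexyl on the saturated ring carbon next to the ring nitrogen are not told apart: a 1.2-fold lower number from compound 2 to compound 3 (0.08 log units; within the scatter). With phenyl held fixed, bromo in place of chloro on a double-bonded ring carbon is the change that reaches beyond the scatter, a 3.4-fold higher number from compound 1 to compound 3 (0.53 log units; beyond the scatter). No measurement at hand accounts for either step.

Still open, going by these compounds, is whether phenyl and cyclohexyl also match when chloro sits on the double-bonded ring carbon. On these data alone, how a fluoro group there, or an amine on the saturated ring carbon, would read also remains unknown.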